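From a Methoxyphenyl Ester to a Naphthyl Ester

This account rests on a few compounds, and the source may have more. Where it says the series, first, only, none or still open, it means among the compounds named here.

Measured so far:
compound 1 `COc1ccc(OC(=O)c2cn(-c3ccccc3)nc2-c2cccnc2)cc1`: > 100000 nM
compound 2 `Cc1ccc(C(C)C)c(OC(=O)c2cn(-c3ccccc3)nc2-c2cccnc2)c1`: 22700 nM
compound 3 `COc1ccc(OC(=O)c2cn(-c3ccccc3)nc2-c2ccncc2)cc1`: > 100000 nM

In a functional assay on HL-60 cells (Homo sapiens) for cytotoxicity, read by MTT assay, with a stated time of 48 h (a lower number here means a stronger inhibitor, a higher number a weaker inhibitor), compound 3 gives only a limit, > 100000 nM. Compound 1 also sits at a limit in this assay, > 100000 nM. Within the data shown here, compound 2 is the one member of the set with a number, 22700 nM in this assay. Two of the three results therefore share (the limit of > 100000 nM in this assay, at which 2 of the 3 values shown sit), and the step that the two limits leave unreadable from compound 1 to compound 3 cannot be read.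

Compound 4, `O=C(Oc1ccc2ccccc2c1)c1cn(-c2ccccc2)nc1-c1ccncc1`, is the next ester in the series. It differs from compound 3 by naphthalen-2-yl in place of 4-methoxyphenyl on an oxygen next to a carbonyl group. Among the measured compounds shown here, the one measured step that bears on such a change at this oxygen is an at least 4.4-fold lower number from compound 1 to compound 2 (0.64 log units; beyond the scatter), where the 4-methoxyphenyl likewise gave way to another aryl group. Compound 4 is therefore expected to move in the same direction, to a lower number, though since compound 3 stands at a limit the size of an at least 3.3-fold lower number from compound 3 to compound 4 (0.52 log units; beyond the scatter) is only an estimate. Compound 4 is expected to give about 30000 nM, within 8000 nM to 100000 nM.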

Compound 4, half-maximal inhibitory concentration: > 100000 nM
Compound 4: no number, only a limit; the forecaster's own chance of this, stated with the estimate: 35%; middle value at least 3.3-fold (0.52 log units) from the limit.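

Compound 3 and compound 4 each give only a limit, so the step from one to the other cannot be read: the limit of > 100000 nM in this assay, at which 3 of the 4 values shown sit.

The compounds shown leave open whether naphthalen-2-yl in place of 4-methoxyphenyl on this oxygen changes the result in this assay at all.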